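A few compounds are considered here, and "the series" means these few. Any claim that something is new, unique, unknown or untested is made for them only; others in the source may bear on it.

Compound 1 `Oc1ccc(-c2cc(-c3ccc(O)cc3)nc(-c3ccc(O)cc3)c2)cc1` carries three 4-hydroxyphenyl groups on the shared core. Among the compounds with values here, in a functional assay on HCT-15 cells (Homo sapiens) for cytotoxicity, read by CCK-8 assay, with a stated time of 4 days (a higher number here means a weaker inhibitor, a lower number a stronger inhibitor), compound 1 gives 5120 nM, and this is the only actual number in this assay. Compound 2 `Oc1ccc(-c2cc(-c3cccc(O)c3)cc(-c3ccc(O)cc3)n2)cc1` differs from compound 1 in one group only. In this assay compound 2 gives > 50000 nM, which is a limit of the assay rather than a measured number (the limit of > 50000 nM in this assay, at which 1 of the 2 values shown sits). The resulting step, an at least 9.7-fold higher number from compound 1 to compound 2 (0.98 log units; beyond the scatter), shows that shifting the hydroxyl within one of the rings weakens the compound clearly.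

Compound 3 `Oc1ccc(-c2cc(-c3ccc(O)cc3)nc(-c3ccccc3O)c2)cc1` is related to compound 1 by a change of the same kind: 2-hydroxyphenyl in place of 4-hydroxyphenyl on an aromatic carbon. Within the data shown here, the one measured step that bears on this change is the one from compound 1 to compound 2, and it was a weakening, so a weakening is expected here too, though its size is uncertain because only the limit of > 50000 nM in this assay, at which 1 of the 2 values shown sits, bounds the earlier step. For compound 3 in this assay the expected step is a 3.9-fold higher number from compound 1 to compound 3 (0.59 log units; beyond the scatter). Compound 3 is therefore estimated at 20000 nM, with a likely range from 5000 nM to 80000 nM.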

Compound 3, half-maximal inhibitory concentration: > 50000 nM
Compound 3: no number, only a limit (the forecaster's own chance of this, stated with the estimate: 35%); middle value at least 2.5-fold (0.39 log units) away from the limit.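

With 2-hydroxyphenyl in place of 4-hydroxyphenyl next to the ring nitrogen, this assay shows an at least 9.7-fold higher number from compound 1 to compound 3 (0.98 log units; beyond the scatter), so this position on the shared core also loses activity when the hydroxyl moves within its ring. For compound 3 the result > 50000 nM is a limit of the assay and not a number, so the step gives only a lower bound on the loss. Among the three compounds, both with a shifted hydroxyl lie at the top of the range that can be read, while only compound 1, with three 4-hydroxyphenyl groups, gives an actual number: the limit of > 50000 nM in this assay, at which 2 of the 3 values shown sit.

As far as these compounds go, what remains open is whether the hydroxyl itself matters at this position, or whether a plain phenyl, a 4-methoxyphenyl or a 4-aminophenyl group could stand in for 4-hydroxyphenyl here and keep a measurable value. From the compounds shown here alone, the true sizes of the losses also stay unknown, since compound 3 and compound 2 are each known only by a limit and neither can be placed more exactly.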